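The compounds below may be only part of what the source reports. "The series", "measured", "known", "first", "only" and "open" are said of these compounds alone.

Measured compounds:
Compound 1, `Oc1ccccc1-c1cc(-c2ccccc2C(F)(F)F)cc(-c2ccccc2O)n1`: 3970 nM
Compound 2, `Oc1ccccc1-c1cc(-c2cccc(C(F)(F)F)c2)cc(-c2ccccc2O)n1`: a limit of the assay, > 50000 nM
Compound 3, `Oc1ccc(-c2cc(-c3ccccc3C(F)(F)F)cc(-c3ccc(O)cc3)n2)cc1`: a limit of the assay, > 50000 nM

All three were tested in a functional assay on HCT-15 cells (Homo sapiens) for inhibition; a higher number here means a weaker inhibitor, a lower number a stronger inhibitor. Compound 1 gives 3970 nM. For compound 2 the result is a limit, not a number, > 50000 nM. For compound 3 the result is likewise a limit, > 50000 nM. Compound 1 and compound 2 differ in one place, (3-(trifluoromethyl)phenyl in place of 2-(trifluoromethyl)phenyl on an aromatic carbon), and this gave an at least 12-fold higher number from compound 1 to compound 2 (1.10 log units; beyond the scatter). How the core of compound 3 differs from the core of compound 1 is not broken down here. The unmeasured compound 4, `Oc1ccc(-c2cc(-c3cccc(C(F)(F)F)c3)cc(-c3ccc(O)cc3)n2)cc1`, carries the change (3-(trifluoromethyl)phenyl in place of 2-(trifluoromethyl)phenyl on an aromatic carbon). The place is not the same word for word: here it is meta to two 4-hydroxyphenyl groups rather than two 2-hydroxyphenyl groups, so this is the same kind of change, not the same one. In this assay the expected step is a step that the limit leaves unreadable from compound 3 to compound 4, set beside an at least 12-fold higher number from compound 1 to compound 2 (1.10 log units; beyond the scatter). This expectation rests on compound 3 giving only a limit, > 50000 nM, and on (the limit of > 50000 nM in this assay, at which 2 of the 3 values shown sit). Compound 4 is estimated at 150000 nM, most likely reported again only as a limit.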

Compound 4, half-maximal inhibitory concentration: > 50000 nM
Compound 4: no number, only a limit; the forecaster's own chance of this, stated with the estimate: 90%; the middle value lies beyond the limit too.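

In this assay, within the data shown here, compound 3 and compound 4 both give only a limit and not a number, so no step between them can be read. Still open, as far as these compounds go, is whether 3-(trifluoromethyl)phenyl in place of 2-(trifluoromethyl)phenyl changes anything when two 4-hydroxyphenyl groups are present, set beside an at least 12-fold higher number from compound 1 to compound 2 (1.10 log units; beyond the scatter).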